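A few compounds are considered here, and "the series" means these few. Any claim that something is new, unique, unknown or untested is made for them only; others in the source may bear on it.

Of the compounds shown here, three built on a shared core have been tested in an ADME assay on 16HBE14o- cells (Homo sapiens) for cytotoxicity, read by MTT assay, with a stated time of 72 h; a lower number here means that less compound is tolerated, a higher number that more compound is tolerated. Compound 1 `N#Cc1ccccc1-c1cc(-c2cc(Cl)cc(OCCC(F)(F)F)c2)c(=O)n(-c2cccnc2)c1` carries a 3,3,3-trifluoropropoxy chain, and in this assay compound 1 gives 25000 nM. Compound 2 `Cc1scnc1COc1cc(Cl)cc(-c2cc(-c3c[nH]c(=O)[nH]c3=O)cn(-c3cccnc3)c2=O)c1` gives 22000 nM in this assay. Compound 3 `Cn1cc(-c2cc(-c3cc(Cl)cc(OCC4CC4)c3)c(=O)n(-c3cccnc3)c2)c(=O)[nH]c1=O` carries a cyclopropylmethoxy chain instead, and for compound 3 the assay reports only a limit, > 100000 nM, so no number is known for it; this is the limit of > 100000 nM in this assay, at which 1 of the 3 values shown sits. Compound 1 and compound 2 both give numbers within the reach of the assay, and those two numbers lie within the usual scatter of each other.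

Compound 4 `Cn1cc(-c2cc(-c3cc(Cl)cc(OCCC(F)(F)F)c3)c(=O)n(-c3cccnc3)c2)c(=O)[nH]c1=O` has not yet been measured. It differs from compound 3 in one place: 2,2,2-trifluoroethyl in place of cyclopropyl on a saturated chain carbon bound to an oxygen on an aromatic ring. Compound 1 also carries the 3,3,3-trifluoropropoxy chain, with a different group elsewhere on the core, and gives a number rather than a limit. Among the measured compounds shown here, no step between measured compounds that differ in a single place is available, so the expectation rests on this comparison alone. The step from compound 3 to compound 4 is expected to be an at least 1.6-fold lower number from compound 3 to compound 4 (0.22 log units; that floor lies within the scatter), toward a somewhat lower tolerated concentration. Compound 4 is estimated to give 60000 nM in this assay, within a range from 20000 nM to 100000 nM.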

Compound 4, half-maximal cytotoxic concentration: 95000 nM
Compound 4: middle estimate off by 1.6-fold (0.20 log units), on the low side; measured number inside the range.
By their numbers in this assay, from the lowest: compounds 2 and 1 (each within the scatter of the next); then compound 4. At a limit, above all of these: compound 3.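

Placing the 3,3,3-trifluoropropoxy chain where compound 3 has cyclopropylmethoxy gives a number that can be read in this assay: compound 4 gives 95000 nM. That change amounts to an at least 1.0-fold lower number from compound 3 to compound 4 (0.02 log units; that floor lies within the scatter), which is only a floor and not a true size, since compound 3 has a limit and not a number: the limit of > 100000 nM in this assay, at which 1 of the 4 values shown sits. Compound 1 and compound 4 share the 3,3,3-trifluoropropoxy chain and differ in the group on an aromatic carbon, and a 3.8-fold higher number from compound 1 to compound 4 (0.58 log units; beyond the scatter), so this chain does not set the tolerated concentration on its own.

Among the compounds shown here, it remains open how far compound 3 really lies from compound 4, and whether cyclopropylmethoxy would keep the same relation to 3,3,3-trifluoropropoxy if the group on the aromatic carbon were the one found in compound 1. Also open, from the compounds shown here alone, is how this position would respond to a plain methoxy, a longer chain of carbon atoms, or a chain ending in an amine or a carboxylic acid.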